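A few compounds are considered here, and "the series" means these few. Any claim that something is new, unique, unknown or untested is made for them only; others in the source may bear on it.

Among the measured compounds shown here, in a functional assay on COLO 205 cells (Homo sapiens) for inhibition, read by sulforhodamine B assay, with a stated time of 48 h, tested at 50 uM (a lower number here means less inhibition of growth, a higher number more inhibition of growth at the concentration tested), compound 1 `COc1ccccc1/C=C/C(=O)/C=C/c1ccc(OCc2cn(CCCOc3cc(=O)oc4ccccc34)nn2)c(OC)c1` gives 57%, the lowest of the three numbers measured so far. Compound 3 `COc1ccc(/C=C/C(=O)/C=C/c2ccc(OCc3cn(CCOc4cc(=O)oc5ccccc45)nn3)c(OC)c2)cc1` stands nearest at 68%, and compound 2 `COc1ccc(/C=C/C(=O)/C=C/c2ccc(OCc3cn(CCOc4cc(=O)oc5ccccc45)nn3)c(OC)c2)cc1OC` stands furthest at 80%, both beyond the scatter above compound 1. Compound 4 `COc1cc(/C=C/C(=O)/C=C/c2cccs2)ccc1OCc1cn(CCCOc2cc(=O)oc3ccccc23)nn1` has not yet been measured. It carries thiophen-2-yl in place of 2-methoxyphenyl on a double-bonded chain carbon bound to a double-bonded chain carbon. For the measured compounds named here, only one measured step bears on this change, and only loosely, as it also removes a methoxy group from an aromatic carbon: a number 12 percentage points lower from compound 2 to compound 3 (beyond the scatter). Going by the values given here, that modest step shows that a small edit can move the number, but no measured compound carries thiophen-2-yl, so the direction remains uncertain. Among the compounds with values here, with compound 1 at 57% and the other two values higher, a small upward move is expected, no larger than that step. The estimated move is a number 6 percentage points higher from compound 1 to compound 4 (within the scatter), which may not clear the scatter. For compound 4 the expected value is 63%, with an estimated range from 45% to 80%.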

Compound 4, percent growth inhibition at one concentration: 55%
Beside the measured number, compound 4's estimate is 8 percentage points above it; the range from low to high includes it.
By their numbers in this assay, from the lowest: compounds 4 and 1 (each within the scatter of the next); then compound 3; then compound 2.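

In this assay, among the compounds shown here, the step with thiophen-2-yl in place of 2-methoxyphenyl on a double-bonded chain carbon bound to a double-bonded chain carbon is a number 2 percentage points lower from compound 1 to compound 4 (within the scatter), the first direct reading at this position. It shows that this aromatic ring can be exchanged here, a five-membered aromatic ring with 1 hetero atom entering for a six-membered aromatic ring of carbon only, with no difference that can be told from the scatter. Nothing given here accounts for why the number holds across this change. The compounds shown leave open whether a different group at this place, such as a ring carrying an amine or a carboxylic acid, would move the number. They also leave open whether thiophen-2-yl would read the same on the core of compound 2.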